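Shortening the long chain of compound 1

A few compounds are considered here, and "the series" means these few. Any claim that something is new, unique, unknown or untested is made for them only; others in the source may bear on it.

Compound 1 `CCCCCCCCCCCCCC(=O)Nc1nnc(S[C@@H]2O[C@H](COC(C)=O)[C@H](OC(C)=O)[C@H](OC(C)=O)[C@H]2OC(C)=O)s1` is a long-chain amide whose hydroxyl groups are capped as acetates. In a functional assay on HeLa cells (Homo sapiens) for cytotoxicity, read by MTT assay, with a stated time of 24 h (on this read-out lower numbers stand for stronger inhibition and higher numbers for weaker inhibition), compound 1 gives 61300 nM as its reading, which puts it at the weak end of the three measured compounds. Compound 2 `CCCCCCCC(=O)Nc1nnc(S[C@@H]2O[C@H](CO)[C@H](O)[C@H](O)[C@H]2O)s1` has a shorter chain and free hydroxyl groups, and compound 2 reads 50800 nM in this assay as well, within the scatter of compound 1. Compound 3 `CCCCCCCC/C=C\CCCCCCCCCCCC(=O)Nc1nnc(S[C@@H]2O[C@H](CO)[C@H](O)[C@H](O)[C@H]2O)s1` has a longer, unsaturated chain and free hydroxyl groups. Compound 3 reads 13500 nM on the same test, lower than compound 1 by more than the scatter.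

Compound 4 `CCCCCCCCCC(=O)Nc1nnc(S[C@@H]2O[C@H](COC(C)=O)[C@H](OC(C)=O)[C@H](OC(C)=O)[C@H]2OC(C)=O)s1` keeps the acetates and shortens the chain: hydrogen in place of butyl on a saturated chain carbon, nine bonds along the chain from a carbonyl carbon in words, hydrogen in place of butyl on a saturated chain carbon, nine bonds along the chain from a carbonyl carbon. Among the compounds with values here, no two measured compounds differ in one place only, so no measured step sizes this change. Compound 2 and compound 3 differ in both chain length and unsaturation, so they cannot isolate length. In this assay I expect no step beyond the scatter, since compound 1 and compound 2 already sit close despite their different chains. The estimated step of a 1.0-fold lower number from compound 1 to compound 4 (0.01 log units; within the scatter) is small. Compound 4 is expected at 60000 nM with a range from 30000 nM to 120000 nM as the estimate.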

Compound 4, half-maximal inhibitory concentration: 44900 nM
For compound 4 the middle estimate is 1.3-fold (0.13 log units) above the measured one; low and high end bracket the measured number.
By their numbers in this assay, from the lowest: compound 3; then compounds 4, 2 and 1 (each within the scatter of the next).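

In this assay, putting hydrogen in place of butyl on a saturated chain carbon, nine bonds along the chain from a carbonyl carbon, gives a 1.4-fold lower number from compound 1 to compound 4 (0.14 log units; within the scatter) as the measured step. This is the first pair shown that differs in one place only, so it is the first direct reading of this change: with the acetates kept, removing the butyl and its 4 carbon atoms leaves the result within the ordinary spread of repeated measurements. At this position, butyl and hydrogen cannot be told apart on this read-out, and no separate evidence is available to explain the result.

A single step on the acetate-capped series leaves open whether the same change would read the same way with free hydroxyl groups. It also leaves open what a longer chain than that of compound 1 would do, or what an amine or a carboxylic acid would do at this place on the chain, with the rest of the compound unchanged.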